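Lengthening a sulfur chain from propyl to butyl

The source may hold more compounds than are shown below. What is called first, only, known or untested is meant among the compounds shown, and "the series" means these compounds.

In an ADME assay on MT4 cells (Homo sapiens) for activation, read by MTT assay (a higher number here means that more compound is tolerated, a lower number that less compound is tolerated), the measured compounds give:
- Compound 1 `CCc1c(C(C)c2c(F)cccc2F)nc(SC(C)C)[nH]c1=O` gives > 3000 nM as a limit
- Compound 2 `CCCSc1nc(C(C)c2c(F)cccc2F)c(CC)c(=O)[nH]1` gives > 3000 nM as a limit

Compound 2 stands at > 3000 nM in this assay and this is a limit of the assay, not a number. Compound 3 `CCCCSc1nc(C(C)c2c(F)cccc2F)c(CC)c(=O)[nH]1` differs from compound 2 by methyl in place of hydrogen on a saturated chain carbon, three bonds along the chain from a sulfur so that propyl on the sulfur becomes butyl. Among the compounds with values here, only one measured step bears on this, a step that the two limits leave unreadable from compound 1 to compound 2 for propyl in place of isopropyl on a sulfur, and it offers no size to carry over. Within the data shown here, the only evidence is the limit of > 3000 nM in this assay, at which 2 of the 2 values shown sit, and it gives no direction. No shift beyond the usual scatter is therefore expected, and compound 3 will probably report a limit too. The expected step is a step that the limit leaves unreadable from compound 2 to compound 3 in size, as an estimate only. For compound 3 the estimated value is 3500 nM with an expected range from 1500 nM to 10000 nM in this assay.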

Compound 3, half-maximal cytotoxic concentration: > 3000 nM
Compound 3: no number, only a limit; the forecaster's own chance of this, stated with the estimate: 75%; the middle value does not contradict the limit.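

The steps among compound 1, compound 2 and compound 3 cannot be read, as each result in this assay is a limit and not a number: the limit of > 3000 nM in this assay, at which 3 of the 3 values shown sit.

From the compounds shown here alone, whether the length or branching of the chain on the sulfur changes the tolerated concentration at all remains open.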